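Acid ceramidase series: chain extension on the phenylpropyl side chain

The source may report more compounds than this note shows. Statements on the series, on what has been measured and on what is new or still open speak of the compounds shown alone.

Compound 1 `O=C(NCCCc1ccccc1)n1c(=O)oc2ccccc21` is the reference point of the pair measured so far. In an assay on HEK293 cells for inhibition of acid ceramidase (Homo sapiens), with a stated time of 10 min (a lower number here means a stronger inhibitor, a higher number a weaker inhibitor), compound 1 gives 55 nM, the lowest of the two numbers, though the gap to the other measured compound lies within the usual scatter. Compound 2 `COc1ccc(-c2ccc3c(c2)oc(=O)n3C(=O)NCCCCc2ccccc2)cc1`, which carries a different core and a longer side chain, gives in this assay 67 nM; the two values sit close together and no ordering can be drawn from them.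

Compound 3 `O=C(NCCCCCc1ccccc1)n1c(=O)oc2ccccc21` has not yet been measured in this assay. Its difference from compound 1 is phenethyl in place of phenyl on a saturated chain carbon, three bonds along the chain from an amide-type nitrogen. Among the compounds with values here, no measured pair in the set isolates this change. Since the longer-chained compound 2 gives 67 nM in this assay, the series seems to tolerate chain length; a small loss or no change beyond the scatter is expected, with the step from compound 1 to compound 3 estimated at a 1.5-fold higher number from compound 1 to compound 3 (0.19 log units; within the scatter). For compound 3 the expected value in this assay is 85 nM, within an estimated range from 30 nM to 250 nM.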

Compound 3, half-maximal inhibitory concentration: 54 nM
Compound 3: middle estimate off by 1.6-fold (0.20 log units), on the high side; low and high end bracket the measured number.
By their numbers in this assay, from the lowest: compounds 3, 1 and 2 (each within the scatter of the next).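

The series now has its first step between compounds that differ in one place: with the core held fixed, phenethyl in place of phenyl on a saturated chain carbon, three bonds along the chain from an amide-type nitrogen, gives a 1.0-fold lower number from compound 1 to compound 3 (0.01 log units; within the scatter) in this assay. This position therefore accepts the larger phenethyl group without a step beyond the scatter, which compound 2 could not show, as it differs from compound 1 in its core as well as in its side chain. No measurement on hand bears on why the two values fall within the scatter of each other.

This is a single step in a single assay, so it sets no trend with chain length and gives no limit to the length accepted at this position. Open, on these data alone, is whether a still longer chain, a shorter chain, or an amine or a carboxylic acid placed on the chain would keep the number within the scatter of compound 1 in this assay.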